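Para-halogen swap on the pendant phenyl ring

The source may hold more compounds than are shown below. What is called first, only, known or untested is meant among the compounds shown, and "the series" means these compounds.

Three analogues share a common core. Compound 1 `Cn1ccc2c(Oc3ccc(NC(=O)c4cc5cccnc5n(-c5ccc(Cl)cc5)c4=O)cc3)ccnc21` gives 730 nM in a functional assay on HT-29 cells (Homo sapiens) for antiproliferative activity, read by MTT assay, with a stated time of 72 h; a lower number here means a stronger inhibitor, a higher number a weaker inhibitor. Compound 2 `Cn1ccc2c(Oc3ccc(NC(=O)c4cc5cccnc5n(-c5ccccc5)c4=O)cc3F)ccnc21` gives 510 nM, and compound 3 `Cn1ccc2c(Oc3ccc(NC(=O)c4cc5cccnc5n(-c5ccc(F)cc5)c4=O)cc3F)ccnc21` gives 160 nM, the lowest of the three numbers; the nearest is compound 2 and the furthest compound 1, both beyond the scatter.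

Among the compounds with values here, the only single-change step so far is a 3.2-fold lower number from compound 2 to compound 3 (0.50 log units; beyond the scatter), fluoro in place of hydrogen on the pendant phenyl ring. Compound 4 `Cn1ccc2c(Oc3ccc(NC(=O)c4cc5cccnc5n(-c5ccc(Cl)cc5)c4=O)cc3F)ccnc21` differs from compound 3 by chloro in place of fluoro on an aromatic carbon. Within the data shown here, no measured pair isolates this swap. Compound 1 carries the same 4-chlorophenyl group but lacks the fluoro on the central ring, so its number of 730 nM cannot be read directly onto compound 4.

Given that the 4-fluorophenyl analogue already sits lowest, the exchange from fluoro to chloro is expected to move the number little, so the step from compound 3 to compound 4 is estimated as a 1.4-fold higher number from compound 3 to compound 4 (0.14 log units; within the scatter). Compound 4 is therefore expected near 220 nM, within a range of 80 nM to 600 nM.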

Compound 4, half-maximal inhibitory concentration: 220 nM
Compound 4: middle estimate and measured number agree at the digits printed; low and high end bracket the measured number.
By their numbers in this assay, from the lowest: compounds 3 and 4 (each within the scatter of the next); then compounds 2 and 1 (each within the scatter of the next).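

In this assay, chloro and fluoro are interchangeable at this position on the core of compound 3 (a 1.4-fold higher number from compound 3 to compound 4 (0.14 log units; within the scatter)). Chloro in place of hydrogen on the same carbon also gives a step beyond the scatter (a 2.3-fold lower number from compound 2 to compound 4 (0.37 log units; beyond the scatter)), so the gain over the unsubstituted phenyl ring of compound 2 is no longer tied to fluoro alone. Fluoro in place of hydrogen can now be read on a second pair (a 3.3-fold lower number from compound 1 to compound 4 (0.52 log units; beyond the scatter)), although there it sits on the other ring, and the two steps match in size: the same change on two cores in this assay, a 3.2-fold lower number (0.50 log units; beyond the scatter) from compound 2 to compound 3 and a 3.3-fold lower number (0.52 log units; beyond the scatter) from compound 1 to compound 4, 1.0-fold (0.02 log units) apart, within the scatter of two such steps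

On these data alone, only hydrogen, fluoro and chloro are compared at this carbon, so the effect of a bromo, a methoxy group or an amine there remains open. As far as these compounds go, whether chloro and fluoro stay interchangeable on the core of compound 1 also remains open.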